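This account rests on a few compounds, and the source may have more. Where it says the series, first, only, none or still open, it means among the compounds named here.

Three compounds of a shared core have been examined in an assay on CHO cells for displacement of a labelled ligand from 5-hydroxytryptamine receptor 7 (Homo sapiens); a lower number here means a stronger inhibitor, a higher number a weaker inhibitor. Compound 1 `CCC1(CCCCN2CCN(c3cccc(Cl)c3)CC2)C(=O)Nc2ccccc21` gives 0.41 nM in this assay, the lowest of the three numbers. Compound 3 `CCC1(CCCCN2CCN(c3ccc(F)cc3)CC2)C(=O)Nc2ccc(F)cc21` gives 1.5 nM in this assay, and compound 2 `CCC1(CCCCN2CCN(c3ccc(Cl)cc3)CC2)C(=O)Nc2c(Cl)cc(F)cc21` gives 5.97 nM in this assay. Both of these gaps to compound 1 lie beyond the usual scatter, so compound 1 stands as the strongest of the three measured.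

Compound 4 `CCC1(CCCCN2CCN(c3cccc(OC)c3)CC2)C(=O)Nc2ccccc21` has not yet been measured. It differs from compound 1 in one place: methoxy in place of chloro on an aromatic carbon, meta to a large group. Among the measured compounds shown here, no measured pair in this set shows this same change, so no step can be read directly from the data. Because compound 1 gives 0.41 nM, a modest weakening is expected rather than a gain, of a size near the edge of the scatter. The expected step from compound 1 to compound 4 is a 2.4-fold higher number from compound 1 to compound 4 (0.39 log units; beyond the scatter). Compound 4 is thus estimated at 1 nM in this assay, within a range from 0.3 nM to 3.5 nM.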

Compound 4, inhibition constant: 2.55 nM
Beside the measured number, compound 4's estimate is 2.6-fold (0.41 log units) below it; low and high end bracket the measured number.
By their numbers in this assay, from the lowest: compound 1; then compounds 3 and 4 (each within the scatter of the next); then compound 2.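

Methoxy in place of chloro on this aromatic carbon gives a 6.2-fold higher number from compound 1 to compound 4 (0.79 log units; beyond the scatter) in this assay, the first change in the set that can be read on its own, as no earlier pair differed in one place. The number thus responds to the group at this position when the rest of compound 1 is held fixed, although the step is modest and compound 4 still gives 2.55 nM. The data at hand offer no evidence on why this step has its size.

A single pair cannot say how a fluoro, methyl or hydroxy group would fare on this carbon. It also leaves open whether the same exchange would give a step of like size where the core itself carries fluoro, as in compound 3.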